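A few compounds are considered here, and "the series" means these few. Any claim that something is new, unique, unknown or untested is made for them only; others in the source may bear on it.

Measured compounds: compound 2, `O=C(CCCc1ccccc1)Nc1nc2ccccc2c(=O)s1`, with 229 nM in an assay on membranes from brain for displacement of a labelled ligand from adenosine receptor A1 (Rattus norvegicus), read by scintillation counting, with a stated time of 90 min; a lower number here means a stronger inhibitor, a higher number a weaker inhibitor; compound 1, `COc1cccc(CCC(=O)Nc2nc3ccccc3c(=O)s2)c1`, with 367 nM in this assay.

On these two numbers compound 2 has the lower one, but the step of a 1.6-fold lower number from compound 1 to compound 2 (0.20 log units; within the scatter) is within the scatter, so no order between compound 1 and compound 2 can be claimed. Compound 3, `O=C(CCc1ccccc1Br)Nc1nc2ccccc2c(=O)s1`, is not yet measured in this assay. It differs from compound 2 by 2-bromophenyl in place of benzyl on a saturated chain carbon, two bonds along the chain from a carbonyl carbon. Going by the values given here, the one measured step that bears on this kind of change, a 1.6-fold lower number from compound 1 to compound 2 (0.20 log units; within the scatter), exchanged one aryl-bearing chain end for another and stayed within the scatter. Nothing here shows a bromine on the ring, so the expectation rests on that single step alone, and compound 3 is expected to stay close to compound 2, with a step of a 1.3-fold higher number from compound 2 to compound 3 (0.12 log units; within the scatter) that does not clearly leave the scatter. Compound 3 is estimated at 300 nM, within 120 nM to 750 nM.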

Compound 3, inhibition constant: > 10000 nM
Compound 3: only a limit was reported; the forecaster's own chance of this, stated with the estimate: 3%; at least 33-fold (1.52 log units) between middle value and limit.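

The chain position two bonds along from the carbonyl carbon turns out not to accept every aryl group alike: the exchange between compound 1 and compound 2 stayed within the scatter, but 2-bromophenyl gives an at least 43-fold higher number from compound 2 to compound 3 (1.64 log units; beyond the scatter) and an at least 27-fold higher number from compound 1 to compound 3 (1.43 log units; beyond the scatter). Benzyl and 2-bromophenyl have the same count of heavy atoms, the same kind of ring and no net charge, so these counts do not separate a tolerated group from one that is not. In this assay compound 3 has only a limit and not a number: the limit of > 10000 nM in this assay, at which 1 of the 3 values shown sits.

On these data alone, how far compound 3 actually lies beyond that limit stays unknown. The compounds shown also leave open whether the bromine itself or its place on the ring goes with this step, which 3-bromophenyl, 2-methoxyphenyl or an unsubstituted phenyl on the same chain could separate.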